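The source may hold more compounds than are shown below. What is called first, only, known or untested is meant among the compounds shown, and "the series" means these compounds.

Compound 2 `O=C(O)c1cnc(-c2ccccc2Cl)[nH]c1=O` belongs to a set of three analogues built on one shared core, alongside compound 1 `O=C(O)c1cnc(-c2ccccc2)[nH]c1=O` and compound 3 `CCCCCOc1ccccc1-c1ncc(C(=O)O)c(=O)[nH]1`. In a functional assay on the whole organism (strain Sprague-Dawley) for inhibition, with Rattus norvegicus as the target, with a stated time of 10 min (on this read-out higher numbers stand for an effect only at larger amounts of compound and lower numbers for an effect already at smaller amounts), compound 2 gives 5 mg/kg, compound 1 gives 50 mg/kg and compound 3 gives 3 mg/kg; compound 2 thus stands well away from compound 1 and close to compound 3. Compound 4 `C=CCOc1ccccc1-c1ncc(C(=O)O)c(=O)[nH]1` differs from compound 2 by allyloxy in place of chloro on an aromatic carbon. Within the data shown here, two measured steps bear on this change: a 10-fold lower number from compound 1 to compound 2 (1.00 log units; beyond the scatter) and a 1.7-fold lower number from compound 2 to compound 3 (0.22 log units; within the scatter). Since a longer alkoxy chain in place of chloro on the same aromatic carbon gave only a 1.7-fold lower number from compound 2 to compound 3 (0.22 log units; within the scatter), no step beyond the scatter is expected for allyloxy, a 1.3-fold lower number from compound 2 to compound 4 (0.10 log units; within the scatter). Compound 4 is therefore estimated at 4 mg/kg, with a likely range from 1.5 mg/kg to 10 mg/kg.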

Compound 4, dose for 50% inhibition: 0.5 mg/kg
The estimate for compound 4 lay 8.0-fold (0.90 log units) above the measured number; measured number below the stated range.
By their numbers in this assay, from the lowest: compound 4; then compounds 3 and 2 (each within the scatter of the next); then compound 1.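

In this assay, allyloxy on this aromatic carbon clearly outdoes chloro (a 10-fold lower number from compound 2 to compound 4 (1.00 log units; beyond the scatter)), which pentyloxy did not. The chain attached through the oxygen therefore matters, not merely an oxygen-linked group at this position: allyloxy also outdoes pentyloxy (a 6.0-fold lower number from compound 3 to compound 4 (0.78 log units; beyond the scatter)), and the total gain over hydrogen is wide (a 100-fold lower number from compound 1 to compound 4 (2.00 log units; beyond the scatter)). Nothing given here explains this gain. From the compounds shown here alone, whether it comes from the double bond or from the shorter chain stays open, and a propoxy group on the same carbon would separate the two.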